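Two aryl sulfanyl benzamides and an untested isomer

The source may report more compounds than this note shows. Statements on the series, on what has been measured and on what is new or still open speak of the compounds shown alone.

Measured so far:
compound 1, `Cc1cc(C)cc(SCc2ccc(/C=C/C(=O)Nc3ccccc3N)cc2)c1`, 7.98%
compound 2, `CC(C)(C)c1ccc(SCc2ccc(C(=O)Nc3ccccc3N)cc2)cc1`, 4.81%

Compound 1 and compound 2 were tested in a functional assay on HCT-116 cells (Homo sapiens) for inhibition, read by CCK-8 assay, with a stated time of 72 h, tested at 2 uM; a lower number here means less inhibition of growth, a higher number more inhibition of growth at the concentration tested. Compound 1 gives 7.98%, and compound 2 gives 4.81%. Compound 1 holds the higher of the two numbers, but the gap to compound 2 lies within the scatter of the method, so the two cannot be told apart on these data. Both numbers stand low on the scale.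

Compound 3, `CCc1ccc(SCc2ccc(/C=C/C(=O)Nc3ccccc3N)cc2)cc1`, has not been measured yet. Compared with compound 1 it differs in one place: 4-ethylphenyl in place of 3,5-dimethylphenyl on a sulfur. The two compounds contain the same atoms joined differently, and the change sits on the sulfur far from the amide end of the shared core. Within the data shown here, with no measured pair of this kind to lean on, the step from compound 1 to compound 3 is expected to be small, a number 1 percentage points lower from compound 1 to compound 3 (within the scatter), in no particular direction beyond the scatter. In this assay compound 3 is therefore expected to give about 7%, somewhere between 0% and 18%.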

Compound 3, percent growth inhibition at one concentration: 3.29%
Compound 3: middle estimate off by 3.7 percentage points, on the high side; the range from low to high includes it.
By their numbers in this assay, from the lowest: compounds 3, 2 and 1 (each within the scatter of the next).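

Among these compounds, replacing 3,5-dimethylphenyl with 4-ethylphenyl on the sulfur provides the first readable step at this position. In this assay the change gives a number 4.7 percentage points lower from compound 1 to compound 3 (within the scatter) and so does not separate the two compounds, even though the same eight carbon atoms are arranged differently in the group. Moving from this 3,5-dimethylphenyl group to this 4-ethylphenyl group therefore leaves the result low on the scale, and no measured property of either group bears on the outcome.

As far as these compounds go, whether any group on this sulfur can move the number beyond the scatter remains open, for example an aryl ring carrying an amine or a carboxylic acid, or a longer chain in place of the ethyl. From the compounds shown here alone, compound 2 differs from the other two compounds in more than one place, so the contribution of each of its differences also remains open.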